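The compounds below may be only part of what the source reports. "The series", "measured", "known", "first", "only" and "open" are said of these compounds alone.

Working notes on the series. Compound 3 `CCCCCN(CCCCC)C(=O)N1CCN(C(=O)N(c2ccccc2)c2cccc(Br)c2)[C@H](C(=O)O)C1` gives 0.6 nM in an assay for inhibition of Type-2 angiotensin II receptor (Rattus norvegicus) (a lower number here means a stronger inhibitor, a higher number a weaker inhibitor), and stands lowest of the three numbers at hand. Compound 1 `CCCCCN(CCCCC)C(=O)N1CCN(C(=O)N(c2ccccc2)c2ccccc2)[C@@H](C(=O)O)C1` gives 4.5 nM in this assay, and compound 2 `CCCCCN(C)C(=O)N1CCN(C(=O)N(c2ccccc2)c2ccccc2)[C@H](C(=O)O)C1` gives 15 nM; both gaps to compound 3 lie beyond the scatter, the gap to compound 2 being the wider one. For the measured compounds named here, no pair of these three differs in a single place, so no isolated step can be read from them.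

Compound 4 `CCCCCN(CCCCC)C(=O)N1CCN(C(=O)N(c2ccccc2)c2ccc(C(=O)O)cc2)[C@H](C(=O)O)C1` remains to be measured. It differs from compound 3 in one place: 4-carboxyphenyl in place of 3-bromophenyl on an amide-type nitrogen. Going by the values given here, the change swaps a bromine-bearing ring for one bearing a carboxylic acid, and nothing among the measured compounds shows how this assay responds to such a swap. The expectation is a weaker inhibitor than compound 3, with a step beyond the scatter, an 8.3-fold higher number from compound 3 to compound 4 (0.92 log units; beyond the scatter), since the bromine of compound 3 goes with its 0.6 nM. For compound 4 the estimate in this assay is 5 nM, within 1 nM to 30 nM.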

Compound 4, half-maximal inhibitory concentration: 180 nM
The estimate for compound 4 lay 36-fold (1.56 log units) below the measured number; the whole stated range lies below it.
By their numbers in this assay, from the lowest: compound 3; then compound 1; then compound 2; then compound 4.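

In this assay, for the compounds shown here, this is the first step that can be read in one place: 4-carboxyphenyl in place of 3-bromophenyl on the amide-type nitrogen gives a 300-fold higher number from compound 3 to compound 4 (2.48 log units; beyond the scatter), a large step beyond the scatter. Going by these compounds alone, it shows that the binding number is highly sensitive to what this aromatic ring carries, which the earlier compounds, with no single-place pair among them, could not show. Nothing at hand accounts for the size of this step.

On these data alone, the swap removes the bromine, adds a carboxylic acid and changes the place of the substituent named on the ring, so the share of each in the step remains open. Also open, as far as these compounds go, is how this position would respond to a methyl ester, an amine or a chlorine on the same ring.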